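The compounds below may be only part of what the source reports. "The series", "measured", "known", "first", "only" and "open" are said of these compounds alone.

Measured compounds:
- compound 1, `CC(C)=CCC[C@H](C)c1ccc(C)cc1O`, gives 37200 nM
- compound 2, `CC(C)=CCC[C@H](C)c1ccc(C)c2c1OCN(CCCCCO)C2`, gives 10000 nM
- compound 3, `CC(C)=CCC[C@H](C)c1ccc(C)c2c1OCN(CCCCC(=O)O)C2`, gives 29900 nM

In a functional assay on MDA-MB-231 cells (Homo sapiens), read by wound healing assay, with a stated time of 24 h (on this read-out higher numbers stand for weaker inhibition and lower numbers for stronger inhibition), compound 1 stands highest of the three numbers, so it is the weakest inhibitor shown; its value and that of compound 3 lie within the scatter of each other, while compound 2 sits clearly lower. Among the compounds with values here, the one step that can be followed directly, a 3.0-fold higher number from compound 2 to compound 3 (0.48 log units; beyond the scatter), shows that swapping a hydroxymethyl for a carboxy on the chain costs some inhibition.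

Compound 4, `CC(C)=CCC[C@H](C)c1ccc(C)c(CO)c1O`, has not yet been measured. It differs from compound 1 as follows: hydroxymethyl in place of hydrogen on an aromatic carbon. Within the data shown here, this is a small addition; no measured step changes the ring of the shared core in this way, and the chain step between compound 2 and compound 3 involves a different part of the molecule. The values of compound 1 and compound 2 suggest that building onto the core can lower the number, but compound 4 adds only a fragment of what compound 2 carries. A small step, at most modest and toward a lower number, is therefore expected, a 1.4-fold lower number from compound 1 to compound 4 (0.16 log units; within the scatter). Compound 4 is estimated at 26000 nM, within a range from 11000 nM to 55000 nM.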

Compound 4, half-maximal inhibitory concentration: 12300 nM
The estimate for compound 4 lay 2.1-fold (0.33 log units) above the measured number; low and high end bracket the measured number.
By their numbers in this assay, from the lowest: compounds 2 and 4 (each within the scatter of the next); then compounds 3 and 1 (each within the scatter of the next).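

In this assay, the step of a 3.0-fold lower number from compound 1 to compound 4 (0.48 log units; beyond the scatter) shows that the aromatic ring of the shared core can respond to a very small change. A hydroxymethyl in place of hydrogen on this aromatic carbon, ortho to a hydroxy group and ortho to a methyl group, gives stronger inhibition by a margin beyond the scatter. No measurement at hand explains this gain.

The compounds shown leave open whether the gain needs the hydroxymethyl itself, or whether a methyl, an aminomethyl or a longer chain ending in hydroxy on the same carbon would do the same. They also leave open whether a carboxylic acid at this carbon would weaken inhibition, as carboxy in place of hydroxymethyl did on the chain of compound 2.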